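Replacing a fluorophenyl with pyridinyl on the shared core

A few compounds are considered here, and "the series" means these few. Any claim that something is new, unique, unknown or untested is made for them only; others in the source may bear on it.

Compound 1 `CCCC(Nc1cncc(-c2ccc(O)c(OC)c2)n1)c1ccccc1`: in a functional assay on PC-3 cells (Homo sapiens) for cytotoxicity, read by MTT assay, with a stated time of 72 h (a higher number here means a weaker inhibitor, a lower number a stronger inhibitor), compound 1 gives 160 nM
Compound 2 `CCCC(Nc1cncc(-c2ccc(O)c(OC)c2)n1)c1ccc(Cl)cc1`: in this assay compound 2 gives 20000 nM
Compound 3 `CCCC(Nc1cncc(-c2ccc(O)c(OC)c2)n1)c1cccc(F)c1`: in this assay compound 3 gives 600 nM

Compound 3 stands second highest of these three numbers: there is a 3.8-fold higher number from compound 1 to compound 3 (0.57 log units; beyond the scatter) and a 33-fold lower number from compound 2 to compound 3 (1.52 log units; beyond the scatter). Compound 4 `CCCC(Nc1cncc(-c2ccc(O)c(OC)c2)n1)c1cccnc1` differs from it by pyridin-3-yl in place of 3-fluorophenyl on a saturated chain carbon bound to a nitrogen on an aromatic ring and a saturated chain carbon. Going by the values given here, no measured step swaps a ring carbon for a ring nitrogen here; the nearest comparisons, a 3.8-fold higher number from compound 1 to compound 3 (0.57 log units; beyond the scatter) and a 130-fold higher number from compound 1 to compound 2 (2.10 log units; beyond the scatter), show that adding a halogen to this ring raised the number, modestly for fluorine and strongly for chlorine. Removing the fluorine while a ring nitrogen enters leaves the direction open, so a small step is expected, with wide uncertainty. The expected step is a 1.3-fold higher number from compound 3 to compound 4 (0.12 log units; within the scatter) in this assay. Compound 4 is estimated at 800 nM, between 150 nM and 5000 nM.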

Compound 4, half-maximal inhibitory concentration: 300 nM
Beside the measured number, compound 4's estimate is 2.7-fold (0.43 log units) above it; measured number inside the range.
By their numbers in this assay, from the lowest: compounds 1, 4 and 3 (each within the scatter of the next, the first and the last beyond it); then compound 2.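

Pyridin-3-yl on this saturated chain carbon stays within the scatter of both phenyl (a 1.9-fold higher number from compound 1 to compound 4 (0.27 log units; within the scatter)) and 3-fluorophenyl (a 2.0-fold lower number from compound 3 to compound 4 (0.30 log units; within the scatter)) in this assay. So a ring nitrogen can enter here without the large rise in the number seen with 4-chlorophenyl (a 67-fold lower number from compound 2 to compound 4 (1.82 log units; beyond the scatter)).

Still open, going by these compounds, is how pyridin-4-yl, an amine on this ring, or a longer chain on this saturated chain carbon would read in this assay. Nothing measured here explains why these groups give the numbers they do.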